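The source may report more compounds than this note shows. Statements on the series, on what has been measured and on what is new or still open speak of the compounds shown alone.

Measured compounds:
compound 1 `COc1c(/C=C2/C(=O)Nc3ccccc32)c2ccccc2n1-c1ccccc1` — 1120 nM
compound 2 `O=C1Nc2ccccc2/C1=C\c1c(Cl)n(CCCc2ccccc2)c2ccccc12` — 13800 nM
compound 3 `COc1c(/C=C2/C(=O)Nc3ccc(Cl)cc32)c2ccccc2n1-c1ccccc1` — 8510 nM

In a functional assay on cells (Cancer cell lines, Homo sapiens) for cytotoxicity, with a stated time of 48 h (a higher number here means a weaker inhibitor of growth, a lower number a stronger inhibitor of growth), compound 1 gives 1120 nM, and compound 3, which carries the change (chloro in place of hydrogen on an aromatic carbon), gives 8510 nM; this is a 7.6-fold higher number from compound 1 to compound 3 (0.88 log units; beyond the scatter). Compound 2 gives 13800 nM in this assay; how its core differs from that of compound 1 is not broken down here, and the values of compound 2 and compound 3 lie within the scatter of each other.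

Compound 4 `O=C1Nc2ccc(Cl)cc2/C1=C\c1c(Cl)n(CCCc2ccccc2)c2ccccc12` is not yet measured. It stands to compound 2 as compound 3 stands to compound 1, through the change (chloro in place of hydrogen on an aromatic carbon), made at a place described in the same words. Compound 4 is therefore expected to show a weakening step a 4.3-fold higher number from compound 2 to compound 4 (0.64 log units; beyond the scatter), resting on the step of a 7.6-fold higher number from compound 1 to compound 3 (0.88 log units; beyond the scatter) seen on the other core. Compound 4 is estimated at 60000 nM in this assay, between 20000 nM and 150000 nM.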

Compound 4, concentration for 50% growth inhibition: 1860 nM
Compound 4: middle estimate off by 32-fold (1.51 log units), on the high side, outside the stated range (below it).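

In this assay the chloro in place of hydrogen on an aromatic carbon acts in opposite directions on the two cores, and on the core of compound 2 it gives a 7.4-fold lower number from compound 2 to compound 4 (0.87 log units; beyond the scatter) and not a rise: the same change on two cores in this assay, a 7.6-fold higher number (0.88 log units; beyond the scatter) from compound 1 to compound 3 and a 7.4-fold lower number (0.87 log units; beyond the scatter) from compound 2 to compound 4, 56-fold (1.75 log units) apart, beyond the scatter of two such steps. The step seen on the core of compound 1 therefore did not carry over to the core of compound 2, in direction or in size. The two cores differ in more than one place, and these two pairs do not tell which difference goes with the reversal, nor do they set a rule for the series.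

As far as these compounds go, it remains open whether a bromo or an amine at the same place would separate the two cores in the same way. From the compounds shown here alone, it is also open how the chloro step would behave on a core that combines the methoxy group with a longer chain.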